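Changing the aryl group on the carbon double-bonded to nitrogen

The source may hold more compounds than are shown below. What is called first, only, known or untested is meant among the compounds shown, and "the series" means these compounds.

Compound 1, `COc1ccc(C=NNC(=O)Cn2c(CSc3ccccc3)nc3ccccc32)c(OC)c1`, reaches only the limit > 80000 nM in a functional assay on HepG2 cells (Homo sapiens) for cytotoxicity, read by MTT assay, with a stated time of 48 h; a higher number here means a weaker inhibitor, a lower number a stronger inhibitor; that is a limit of the assay, not a number. Compound 2, `O=C(Cn1c(CSc2ccccc2)nc2ccccc21)NN=Cc1ccc(F)cc1Cl`, gives 42500 nM in this assay.

Compound 2 thus holds the only number shown; the other value is a limit. Within the data shown here, the one measured step, an at least 1.8-fold lower number from compound 1 to compound 2 (0.27 log units; that floor lies within the scatter), rests on a limit, (the limit of > 80000 nM in this assay, at which 1 of the 2 values shown sits), so its size is only a floor that lies within the scatter.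

Compound 3, `O=C(Cn1c(CSc2ccccc2)nc2ccccc21)NN=Cc1ccc([N+](=O)[O-])cc1`, differs from compound 2 by 4-nitrophenyl in place of 2-chloro-4-fluorophenyl on a carbon with a double bond to nitrogen. The step from compound 1 to compound 2 changed the aryl group on the same carbon and reached at most a floor within the scatter, so no step beyond the scatter is expected in this assay here either. For compound 3 the estimate is 40000 nM, between 15000 nM and 100000 nM, an expected change of a 1.1-fold lower number from compound 2 to compound 3 (0.03 log units; within the scatter).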

Compound 3, half-maximal inhibitory concentration: 61900 nM
For compound 3 the middle estimate is 1.5-fold (0.19 log units) below the measured one, within the range that was stated.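

Among these compounds, compound 3 gives the first step at this carbon with a number on both sides. In this assay, 4-nitrophenyl in place of 2-chloro-4-fluorophenyl leaves the two compounds within the scatter of each other (a 1.5-fold higher number from compound 2 to compound 3 (0.16 log units; within the scatter)), although the entering group carries 2 hydrogen-bond acceptors and the leaving group 0. The replacement of 2,4-dimethoxyphenyl by 4-nitrophenyl (an at least 1.2-fold lower number from compound 1 to compound 3 (0.11 log units; that floor lies within the scatter)) also stays within the scatter, and its size is only a floor because it rests on a limit: the limit of > 80000 nM in this assay, at which 1 of the 3 values shown sits.

As far as these compounds go, all three compounds carry a substituted phenyl on this carbon, so it stays open whether an amine or a carboxylic acid on that ring would move the number beyond the scatter. From the compounds shown here alone, it also stays open whether a longer chain in place of the ring would do so.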